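The source may report more compounds than this note shows. Statements on the series, on what has been measured and on what is new or still open speak of the compounds shown alone.

Three compounds built on one shared core have been run through an ADME assay for permeability, using PAMPA; on this read-out lower numbers stand for lower permeability and higher numbers for higher permeability. Compound 1 `C/C=C/C(=O)Nc1cccc(-c2nc3ccccc3s2)c1` gives 1640 10^-6 cm/s. Compound 2 `CN(C)CCC(=O)Nc1cccc(-c2nc3ccccc3s2)c1` gives 2080 10^-6 cm/s, and the step of a 1.3-fold higher number from compound 1 to compound 2 (0.10 log units; within the scatter) falls within the scatter. Compound 3 `O=C(Nc1cccc(-c2nc3ccccc3s2)c1)c1cnccc1Cl` gives 732 10^-6 cm/s, the lowest of the three numbers; the steps of a 2.2-fold lower number from compound 1 to compound 3 (0.35 log units; beyond the scatter) and a 2.8-fold lower number from compound 2 to compound 3 (0.45 log units; beyond the scatter) are both modest yet beyond the scatter, and each of them replaces the group on the carbonyl carbon.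

Compound 4 `COc1ccc(-c2nc3ccccc3s2)cc1NC(=O)c1cnccc1Cl` differs from compound 3 in one place: methoxy in place of hydrogen on an aromatic carbon, the methoxy entering on an aromatic carbon of a six-membered aromatic ring of carbon only, ortho to a large group and para to the 1,3-benzothiazol-2-yl group. Within the data shown here, none of the measured steps touches this aromatic ring; all three swap the group on the carbonyl carbon, so they offer no direct guide to what a methoxy here does. Among the measured compounds shown here, with no comparable step in hand, the expectation is that compound 4 stays close to compound 3, a change of a 1.0-fold lower number from compound 3 to compound 4 (0.02 log units; within the scatter) in this assay that is expected to sit within the scatter. Compound 4 is therefore estimated at 700 10^-6 cm/s, with a range from 350 10^-6 cm/s to 1400 10^-6 cm/s.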

Compound 4, apparent permeability: 121 10^-6 cm/s
Compound 4: the middle estimate sits 5.8-fold (0.76 log units) above what was measured, and the stated range ends above it.
By their numbers in this assay, from the lowest: compound 4; then compound 3; then compounds 1 and 2 (each within the scatter of the next).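

In this assay this aromatic carbon, ortho to a large group and para to the 1,3-benzothiazol-2-yl group, proves sensitive to substitution: methoxy in place of hydrogen gives a 6.0-fold lower number from compound 3 to compound 4 (0.78 log units; beyond the scatter) and takes the number beyond the scatter. The earlier steps shown here all changed the group on the carbonyl carbon, so they said nothing about this ring, yet this entry of only 2 heavy atoms moves the number further than the largest of those swaps, a 2.8-fold lower number from compound 2 to compound 3 (0.45 log units; beyond the scatter) on the same read-out. Nothing measured here explains why this small change has such a large effect on the number.

The compounds shown leave open whether the step belongs to methoxy in particular or to any group on this aromatic carbon, as a fluorine atom, a hydroxyl or an ethoxy group here would help to tell. They also leave open whether methoxy at this place would shift the number as far with prop-1-en-1-yl or 2-(dimethylamino)ethyl on the carbonyl carbon, as in compound 1 and compound 2, instead of 4-chloropyridin-3-yl.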